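Cytotoxicity notes on a chloroanilinopyrimidine ether series

The source may hold more compounds than are shown below. What is called first, only, known or untested is meant among the compounds shown, and "the series" means these compounds.

Measured compounds:
compound 1 `C/C=C/COc1cc(Nc2ncccn2)ccc1Cl`: 31000 nM
compound 2 `Clc1ccc(Nc2ncccn2)cc1Oc1ccccc1`: 30000 nM
compound 3 `C/C=C/COc1cc(Nc2nccc(OC)n2)ccc1Cl`: 17000 nM

All three were run in an ADME assay on MT2 cells (Homo sapiens) for cytotoxicity; a lower number here means that less compound is tolerated, a higher number that more compound is tolerated. Compound 1 and compound 2 are distinguished by phenyl in place of but-2-en-1-yl on an oxygen on an aromatic ring and the step of a 1.0-fold lower number from compound 1 to compound 2 (0.01 log units; within the scatter) is within the scatter. Compound 1 and compound 3 are distinguished by methoxy in place of hydrogen on an aromatic carbon, with the step of a 1.8-fold lower number from compound 1 to compound 3 (0.26 log units; within the scatter) also within the scatter, so the three numbers cannot be ordered.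

Compound 4 `COc1ccnc(Nc2ccc(Cl)c(Oc3ccccc3)c2)n1` has not yet been run in this assay. It differs from compound 3 by phenyl in place of but-2-en-1-yl on an oxygen on an aromatic ring, the same change that was made from compound 1 to compound 2, at a place described in identical words. The two cores differ by methoxy in place of hydrogen on an aromatic carbon, a methoxy in place of hydrogen on an aromatic carbon.

The expectation for compound 4 rests on the step from compound 1 to compound 2 being a 1.0-fold lower number from compound 1 to compound 2 (0.01 log units; within the scatter): a step of about no change at the digits printed from compound 3 to compound 4 (within the scatter) is expected here as well. Compound 4 is therefore estimated at 17000 nM, in a range of 8500 nM to 34000 nM.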

Compound 4, half-maximal cytotoxic concentration: 38000 nM
For compound 4 the middle estimate is 2.2-fold (0.35 log units) below the measured one; measured number outside the range, above it.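

In this assay, phenyl in place of but-2-en-1-yl on the oxygen gives a 2.2-fold higher number from compound 3 to compound 4 (0.35 log units; beyond the scatter), a modest step, while methoxy in place of hydrogen on the phenyl ether gives a 1.3-fold higher number from compound 2 to compound 4 (0.10 log units; within the scatter). The phenyl change can be treated as carrying from one core to the other as far as these numbers can tell, since the modest step on the methoxy core cannot be separated from the earlier step on the core of compound 1: the same change on two cores in this assay, a 1.0-fold lower number (0.01 log units; within the scatter) from compound 1 to compound 2 and a 2.2-fold higher number (0.35 log units; beyond the scatter) from compound 3 to compound 4, 2.3-fold (0.36 log units) apart, within the scatter of two such steps The methoxy change reads the same way, but with only one pair of steps for each change, these results neither prove that the steps are equal nor show that either change depends on the core: the same change on two cores in this assay, a 1.8-fold lower number (0.26 log units; within the scatter) from compound 1 to compound 3 and a 1.3-fold higher number (0.10 log units; within the scatter) from compound 2 to compound 4, 2.3-fold (0.36 log units) apart, within the scatter of two such steps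

On these data alone, whether a longer chain on the oxygen would fit the same reading remains open. Also open, as far as these compounds go, is how an amine or a carboxylic acid in place of the methoxy would behave when the phenyl change is carried onto that core.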